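The source may report more compounds than this note shows. Statements on the series, on what has been measured and on what is new or still open speak of the compounds shown alone.

Compound 3 `N#C/C(=C\c1c(-c2ccccc2)[nH]c2ccccc12)S(=O)(=O)c1ccccc1` is the weakest of the three compounds measured in a functional assay on A498 cells (Homo sapiens) for inhibition, read by sulforhodamine B assay, with a stated time of 48 h (on this read-out lower numbers stand for stronger inhibition of growth and higher numbers for weaker inhibition of growth), giving 11000 nM. Compound 1 `COc1ccc(-c2[nH]c3ccccc3c2/C=C(\C#N)S(=O)(=O)c2ccccc2)cc1` gives 1100 nM, and compound 2 `CC(=O)/C(=C\c1c(-c2ccccc2)[nH]c2ccccc12)S(=O)(=O)c1ccccc1` gives 2000 nM. The step of a 10-fold higher number from compound 1 to compound 3 (1.00 log units; beyond the scatter) and the step of a 5.5-fold higher number from compound 2 to compound 3 (0.74 log units; beyond the scatter) both weaken growth inhibition. Compound 4 `N#C/C(=C\c1c(-c2ccccc2)[nH]c2ccccc12)C(=O)c1ccccc1` differs from compound 3 by benzoyl in place of phenylsulfonyl on a double-bonded chain carbon bound to a double-bonded chain carbon and a triple-bonded carbon. Neither measured step touches this group, so none of them bears directly on the change from compound 3 to compound 4; they only show that the shared core is sensitive to changes of this size elsewhere. Without a direct precedent, the expected step is a 1.4-fold lower number from compound 3 to compound 4 (0.14 log units; within the scatter), not clearly beyond the scatter. Compound 4 is therefore estimated at 8000 nM, with a range from 2000 nM to 30000 nM.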

Compound 4, concentration for 50% growth inhibition: 15300 nM
Compound 4: the middle estimate sits 1.9-fold (0.28 log units) below what was measured; the range from low to high includes it.
By their numbers in this assay, from the lowest: compounds 1 and 2 (each within the scatter of the next); then compounds 3 and 4 (each within the scatter of the next).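

In this assay, benzoyl in place of phenylsulfonyl gives a 1.4-fold higher number from compound 3 to compound 4 (0.14 log units; within the scatter), so this pair does not separate the two groups at this position. The sulfonyl sulfur is therefore not required to keep growth inhibition at this level, although that level remains weak next to compound 1 and compound 2. Nothing available explains this similarity between the two groups. As far as these compounds go, it remains open whether benzoyl would read the same way on the methoxy-bearing compound 1, and what a carboxylic acid or an amide would do on this carbon.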